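The compounds below may be only part of what the source reports. "The series", "measured", "known", "first", "only" and "open" are said of these compounds alone.

Compound 1 `CC(=O)N1CCN(c2ccc(Nc3nccc(-c4c[nH]c5cccnc45)n3)cc2)CC1` is one of three compounds tested in a functional assay on MV4-11 cells (Homo sapiens) for antiproliferative activity, read by resazurin assay, with a stated time of 72 h; a higher number here means a weaker inhibitor of growth, a lower number a stronger inhibitor of growth. In this assay compound 1 gives 420 nM, the highest of the three numbers. Compound 2 `CC(=O)N1CCN(c2ccc(Nc3ncc(C#N)c(-c4c(C)[nH]c5ccccc45)n3)cc2)CC1` gives 390 nM, which sits within the scatter of compound 1. Compound 3 `CC(=O)N1CCCN(c2cccc(Nc3nccc(-c4cnc5n(C)cccc4-5)n3)c2)CC1` gives 24 nM, a far lower number. Compound 4 `CC(=O)N1CCN(c2ccc(Nc3nccc(-c4nn(C)c5ccccc45)n3)cc2)CC1` has not yet been measured and differs from compound 1 in one place: a group of 10 heavy atoms (8 carbon, 2 nitrogen; one five-membered aromatic ring with 2 hetero atoms, one six-membered aromatic ring of carbon only) in place of a group of 9 heavy atoms (7 carbon, 2 nitrogen; one five-membered aromatic ring with 1 hetero atom, one six-membered aromatic ring with 1 hetero atom), on an aromatic carbon. Going by the values given here, no measured pair shows this same exchange, so the step can only be estimated. The group that leaves carries one hydrogen-bond donor and the group that enters carries none; a moderate weakening is expected, with the step from compound 1 to compound 4 estimated at a 2.1-fold higher number from compound 1 to compound 4 (0.33 log units; beyond the scatter). Compound 4 is expected to give 900 nM, in the range 250 nM to 4000 nM.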

Compound 4, concentration for 50% growth inhibition: 181 nM
Compound 4: middle estimate off by 5.0-fold (0.70 log units), on the high side; measured number outside the range, below it.
By their numbers in this assay, from the lowest: compound 3; then compound 4; then compounds 2 and 1 (each within the scatter of the next).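

In this assay, putting 1-methyl-1H-indazol-3-yl on this aromatic carbon gives a 2.3-fold lower number from compound 1 to compound 4 (0.37 log units; beyond the scatter), so growth inhibition gets stronger. The entering group carries no hydrogen-bond donor, which shows that a donor on this group is not required for this level of activity. Nothing measured here explains the gain. Several features change in this single step, so the compounds shown cannot separate their contributions. Also open, going by these compounds, is how an ethyl group in place of the methyl, or an amine on the six-membered ring, would shift the number.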